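Pendant aryl substituent and antiproliferative potency: iodo to methyl

A few compounds are considered here, and "the series" means these few. Any claim that something is new, unique, unknown or untested is made for them only; others in the source may bear on it.

Three compounds of the shared core have numbers in a functional assay on MOLT-4 cells (Homo sapiens) for antiproliferative activity; a higher number here means a weaker inhibitor, a lower number a stronger inhibitor. Compound 1 `COc1cc(C(=O)c2sc(-c3ccc(Cl)cc3)cc2N)cc(OC)c1OC` gives 77 nM, compound 2 `COc1cc(C(=O)c2sc(-c3ccc(I)cc3)cc2N)cc(OC)c1OC` gives 190 nM, and compound 3 `COc1cc(C(=O)c2sc(-c3ccccc3Cl)cc2N)cc(OC)c1OC` gives 17 nM. Compound 2 stands highest of the three: a 2.5-fold higher number from compound 1 to compound 2 (0.39 log units; beyond the scatter) and an 11-fold lower number from compound 2 to compound 3 (1.05 log units; beyond the scatter), with a 4.5-fold lower number from compound 1 to compound 3 (0.66 log units; beyond the scatter) between the other pair.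

Compound 4 `COc1cc(C(=O)c2sc(-c3ccc(C)cc3)cc2N)cc(OC)c1OC` has not yet been measured. It differs from compound 2 by methyl in place of iodo on an aromatic carbon.

Among the compounds with values here, the only measured step touching this position is a 2.5-fold higher number from compound 1 to compound 2 (0.39 log units; beyond the scatter), a modest change between two halogens; nothing measured involves methyl, and the step from compound 2 to compound 3 moves the substituent rather than exchanging it, so it bears only indirectly. Given that compound 1, with chloro at this position, shows 77 nM, a modest step back toward that number is expected in this assay, though the range must stay wide. The expected step is a 2.1-fold lower number from compound 2 to compound 4 (0.32 log units; beyond the scatter). Compound 4 is estimated at 90 nM, with a range from 35 nM to 250 nM.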

Compound 4, half-maximal inhibitory concentration: 16 nM
The estimate for compound 4 lay 5.6-fold (0.75 log units) above the measured number; the whole stated range lies above it.
By their numbers in this assay, from the lowest: compounds 4 and 3 (each within the scatter of the next); then compound 1; then compound 2.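

At this position in this assay, the exchange between the two halogens gave only a modest step, whereas methyl gives much larger ones: iodo to methyl (a 12-fold lower number from compound 2 to compound 4 (1.07 log units; beyond the scatter)) and chloro to methyl (a 4.8-fold lower number from compound 1 to compound 4 (0.68 log units; beyond the scatter)). The halogen pair therefore did not indicate how a methyl group would behave here. The 4-methylphenyl and 2-chlorophenyl analogues cannot be told apart (a 1.1-fold lower number from compound 3 to compound 4 (0.03 log units; within the scatter)), so a low number in this series does not depend on chloro being moved, and no supporting data bear on the origin of these differences.

Going by these compounds, it remains open whether an ethyl, methoxy or amino group at this position would track methyl or the halogens. The 2-methylphenyl analogue would show whether methyl and chloro also match at that other placement.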